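The compounds below may be only part of what the source reports. "The series", "measured", "known", "first", "only" and "open" are said of these compounds alone.

The study concerns a set of compounds built on one shared core, measured in a functional assay on RAW264.7 cells (Mus musculus) for inhibition, read by ELISA, with stated times of 30 min and 24 h; on this read-out higher numbers stand for weaker inhibition and lower numbers for stronger inhibition. Compound 1 `CN1CCN(c2ccc(NC(=O)c3cc4cc([N+](=O)[O-])ccc4n3Cc3ccc(C(F)(F)F)cc3)cc2)CC1` gives 5090 nM, and compound 2 `CN1CCN(c2ccc(NC(=O)c3cc4cc(NS(C)(=O)=O)ccc4n3Cc3ccc(C(F)(F)F)cc3)cc2)CC1` gives 4910 nM. The step of a 1.0-fold lower number from compound 1 to compound 2 (0.02 log units; within the scatter) shows a nitro group exchanged for a methanesulfonamido group without a change beyond the scatter. Compound 3 `CN1CCN(c2ccc(NC(=O)c3cc4cc(N)ccc4n3Cc3ccc(C(F)(F)F)cc3)cc2)CC1` is reported in this assay as "not active" (no number reported), so no number places it against compounds 1 and 2; it stands only as a compound for which no inhibition was recorded, while the two neighbours sit near each other.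

Compound 4 `C=CC(=O)Nc1ccc2c(c1)cc(C(=O)Nc1ccc(N3CCN(C)CC3)cc1)n2Cc1ccc(C(F)(F)F)cc1` is the compound not yet measured. The change from compound 3 to compound 4 is vinylcarbonyl in place of hydrogen on a nitrogen on an aromatic ring. Among the measured compounds shown here, none of the measured steps bears on this change: the only step recorded swaps nitro for methanesulfonamido on an aromatic carbon and says nothing about a vinylcarbonyl entering on the nitrogen. With compound 3 giving no number, the expectation for compound 4 in this assay can rest only on the values of compounds 1 and 2, and the direction cannot be stated. Compound 4 is therefore estimated at 6000 nM, within a range from 1500 nM to 30000 nM.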

Compound 4, half-maximal inhibitory concentration: 6280 nM
The estimate for compound 4 lay 1.0-fold (0.02 log units) below the measured number, within the range that was stated.
By their numbers in this assay, from the lowest: compounds 2, 1 and 4 (each within the scatter of the next).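

In this assay, compound 4, with vinylcarbonyl on the nitrogen, gives 6280 nM, whereas compound 3, with the free amino group, has no number and is reported as not active, so the step between them cannot be read. The two readable steps, a 1.3-fold higher number from compound 2 to compound 4 (0.11 log units; within the scatter) and a 1.2-fold higher number from compound 1 to compound 4 (0.09 log units; within the scatter), place (vinylcarbonyl)amino with the methanesulfonamido and nitro groups of compounds 2 and 1, so all three groups at this position give values within the scatter of one another. No measurement shown gives a cause for this result.

The compounds shown leave open whether the double bond of vinylcarbonyl matters, which an acetyl or propanoyl group on the same nitrogen would address. They also leave open whether a carboxylic acid or a longer alkyl chain at this position would give a value in the same range.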